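The source may report more compounds than this note shows. Statements on the series, on what has been measured and on what is new or still open speak of the compounds shown alone.

- compound 1 `N#C/C(=C\c1ccccc1OS(=O)(=O)c1ccc([N+](=O)[O-])cc1)C(=O)Nc1nnc(Cc2ccc(F)cc2)s1` gives 55%
- compound 2 `N#C/C(=C\c1ccccc1OS(=O)(=O)c1ccc(F)cc1)C(=O)Nc1nnc(Cc2ccc(F)cc2)s1` gives 59%

Among the measured compounds shown here, in a functional assay on RS4-11 cells (Homo sapiens) for inhibition, read by CCK-8 assay, with a stated time of 48 h, tested at 20 uM (a lower number here means less inhibition of growth, a higher number more inhibition of growth at the concentration tested), compound 1 stands at 55% and lies within the scatter of compound 2, the only other measured compound. Compound 3 `N#C/C(=C\c1ccccc1OS(=O)(=O)c1ccc([N+](=O)[O-])cc1)C(=O)Nc1nnc(Cc2ccc(Cl)cc2)s1` differs from compound 1 by chloro in place of fluoro on an aromatic carbon, 4-fluorobenzyl to 4-chlorobenzyl. For the measured compounds named here, the one measured step, a number 4 percentage points higher from compound 1 to compound 2 (within the scatter), is a change of fluoro in place of nitro on an aromatic carbon, so it does not test this exchange directly. Going by the values given here, it is the only guide, and no step beyond the scatter is expected. The estimate for compound 3 is 57% with an expected range of 42% to 72% in this read-out. This estimate means a number 2 percentage points higher from compound 1 to compound 3 (within the scatter) as the expected change.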

Compound 3, percent growth inhibition at one concentration: 66%
For compound 3 the middle estimate is 9 percentage points below the measured one; the measured number falls inside the stated range.
By their numbers in this assay, from the lowest: compounds 1, 2 and 3 (each within the scatter of the next, the first and the last beyond it).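

In this assay, the change from 4-fluorobenzyl to 4-chlorobenzyl gives a number 11 percentage points higher from compound 1 to compound 3 (beyond the scatter). Among the compounds shown here, this is the first step read at this position, and unlike the earlier exchange of nitro for fluoro, it lies beyond the scatter, so the halogen here is not a neutral choice with the rest of compound 1 held constant. No available data bear on the reason for this step.

Still open, on these data alone, is whether the chloro gain carries over when the sulfonate ring bears fluoro instead of nitro. Also open, as far as these compounds go, is how bromo, methoxy or an amine would read at this position.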